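The source may report more compounds than this note shows. Statements on the series, on what has been measured and on what is new or still open speak of the compounds shown alone.

Compound 2 `CNc1cc(Oc2ccc(NC(=O)Nc3cccc(C(F)(F)F)c3)cc2)ncn1` is the starting point here. In an assay on isolated protein for inhibition of serine/threonine-protein kinase TNNI3K (Homo sapiens) (a higher number here means a weaker inhibitor, a lower number a stronger inhibitor), compound 2 gives 40 nM, the lowest of the two plain numbers in this set. Its closest neighbour is compound 3 `O=C(Nc1ccc(Oc2ccncn2)cc1)Nc1cccc(C(F)(F)F)c1`, which in this assay gives 160 nM; the step of a 4.0-fold higher number from compound 2 to compound 3 (0.60 log units; beyond the scatter) shows that removing the methylamino group weakens inhibition by a modest but real margin. Compound 1 `CCc1cc(NC(=O)Nc2cccc(C(F)(F)F)c2)cc(Cl)c1Oc1cc(NC)ncn1` in this assay gives <= 10 nM, which is a limit of the assay rather than a number. That reading is covered by the limit of <= 10 nM in this assay, at which 1 of the 3 values shown sits.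

Compound 4 `CNc1cc(Oc2ccc(NC(=O)Nc3cccc(C(F)(F)F)c3)cc2Cl)ncn1` differs from compound 2 in one place: chloro in place of hydrogen on an aromatic carbon. Within the data shown here, no measured pair in this set changes a chloro group on its own, so the single measured step, from compound 2 to compound 3, concerns a different group and gives no direct guide. With nothing to point either way, the expectation is a step within the usual scatter, a 1.6-fold lower number from compound 2 to compound 4 (0.20 log units; within the scatter). Compound 4 is therefore estimated to give 25 nM in this assay, with a likely range from 8 nM to 80 nM.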

Compound 4, half-maximal inhibitory concentration: 50 nM
For compound 4 the middle estimate is 2.0-fold (0.30 log units) below the measured one, and the stated range covers the measured number.
By their numbers in this assay, from the lowest: compounds 2 and 4 (each within the scatter of the next); then compound 3. At a limit, below all of these: compound 1.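

In this assay, chloro in place of hydrogen on this aromatic carbon, ortho to a (6-(methylamino)pyrimidin-4-yl)oxy group, shows neither a gain nor a loss (a 1.3-fold higher number from compound 2 to compound 4 (0.10 log units; within the scatter)). The chloro alone therefore does not account for the reading of compound 1, and the ethyl group is what separates that compound from compound 4, with a step beyond the scatter (an at least 5.0-fold higher number from compound 1 to compound 4 (0.69 log units; beyond the scatter)). Compound 1 stands at a limit, so this step gives only a minimum size: the limit of <= 10 nM in this assay, at which 1 of the 4 values shown sits.

From the compounds shown here alone, it remains open whether a fluoro, a methoxy or an amine on this carbon would behave as chloro does. Also open, going by these compounds, is how far ethyl would carry the same effect on a ring without the chloro.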